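Sulfonamide series: chloro to hydroxy on the pendant ring

The compounds below may be only part of what the source reports. "The series", "measured", "known", "first", "only" and "open" are said of these compounds alone.

Working notes. In an assay on cells for inhibition of HSP60/HSP10 (Homo sapiens), with a stated time of 60 min (a higher number here means a weaker inhibitor, a lower number a stronger inhibitor), compound 1 `O=S(=O)(Nc1ccc(-c2nc3ccccc3o2)cc1)c1ccc(F)c(C(F)(F)F)c1` gives 28000 nM. Compound 2 `O=S(=O)(Nc1ccc(-c2nc3ccccc3o2)cc1)c1cccc(Cl)c1` gives 54000 nM in this assay, the higher of the two numbers; compound 1 sits lower by an amount within the scatter, so the two cannot be ordered. Compound 3 `Cc1cccc(S(=O)(=O)Nc2ccc3oc(-c4ccccc4)nc3c2)c1` reaches only a limit of this assay, > 100000 nM, which is the limit of > 100000 nM in this assay, at which 1 of the 3 values shown sits.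

Compound 4 `O=S(=O)(Nc1ccc(-c2nc3ccccc3o2)cc1)c1cccc(O)c1` awaits measurement in this assay. It differs from compound 2 by hydroxy in place of chloro on an aromatic carbon, read one bond further out as 3-chlorophenyl to 3-hydroxyphenyl. For the measured compounds named here, no measured step covers this change. The expectation is a step no larger than the scatter, with the estimated step from compound 2 to compound 4 being a 1.1-fold higher number from compound 2 to compound 4 (0.05 log units; within the scatter). Compound 4 is expected near 60000 nM, estimated between 25000 nM and 150000 nM.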

Compound 4, half-maximal inhibitory concentration: 62000 nM
For compound 4 the middle estimate is 1.0-fold (0.01 log units) below the measured one, within the range that was stated.
By their numbers in this assay, from the lowest: compounds 1, 2 and 4 (each within the scatter of the next, the first and the last beyond it). At a limit, above all of these: compound 3.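

In this assay, for the compounds shown here, the first single-place step reads a 1.1-fold higher number from compound 2 to compound 4 (0.06 log units; within the scatter), with hydroxy in place of chloro on the pendant ring. A hydrogen-bond donor and acceptor can thus enter at this position, meta to a large group, without a readable difference between the two compounds. Compound 3 shows how close the top of the readable range lies to these numbers: the limit of > 100000 nM in this assay, at which 1 of the 4 values shown sits.

As far as these compounds go, whether an amine or a carboxylic acid at this position would move the number beyond the scatter stays open. So does whether a methoxy group would separate from hydroxy.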